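A second methoxy on the anilide ring of compound 2

This account rests on a few compounds, and the source may have more. Where it says the series, first, only, none or still open, it means among the compounds named here.

Two anilides built on a shared core have been measured in a functional assay on HOS cells (Homo sapiens) for inhibition, read by MTT assay, with a stated time of 72 h; on this read-out higher numbers stand for weaker inhibition and lower numbers for stronger inhibition. Compound 1 `Cc1ccc(NC(=O)CCC(=O)OCCCCCCSc2ccc([N+](=O)[O-])c3nonc23)cc1` gives 3340 nM. Compound 2 `COc1ccc(NC(=O)CCC(=O)OCCCCCCSc2ccc([N+](=O)[O-])c3nonc23)cc1` gives 1800 nM in this assay. For the measured compounds named here, the only step between them, a 1.9-fold lower number from compound 1 to compound 2 (0.27 log units; within the scatter), means the two numbers sit within the scatter of each other, so compound 2 cannot be set apart from compound 1 on these data.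

Compound 3 `COc1ccc(NC(=O)CCC(=O)OCCCCCCSc2ccc([N+](=O)[O-])c3nonc23)cc1OC` carries one further change: methoxy in place of hydrogen on an aromatic carbon. Going by the values given here, no measured step describes the entry of a methoxy group for hydrogen, nor a second methoxy on this ring; the single known step, a 1.9-fold lower number from compound 1 to compound 2 (0.27 log units; within the scatter), exchanges methyl for methoxy and stays within the scatter. There is thus no ground to expect a step beyond the scatter in this assay for this addition, in either direction. For compound 3 the expected step is a 1.2-fold lower number from compound 2 to compound 3 (0.08 log units; within the scatter). Compound 3 is therefore estimated at 1500 nM in this assay, with a range from 600 nM to 4000 nM.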

Compound 3, half-maximal inhibitory concentration: 1390 nM
Compound 3: middle estimate off by 1.1-fold (0.03 log units), on the high side, and the stated range covers the measured number.
By their numbers in this assay, from the lowest: compounds 3, 2 and 1 (each within the scatter of the next, the first and the last beyond it).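

In this assay the methoxy group that enters ortho to a methoxy group and meta to a large group gives a 1.3-fold lower number from compound 2 to compound 3 (0.11 log units; within the scatter), so on these data compound 3 cannot be set apart from compound 2, and this aromatic carbon accepts the added group with no readable change in the number. The comparison with the methyl-bearing anilide reads differently: 3,4-dimethoxyphenyl in place of 4-methylphenyl gives a 2.4-fold lower number from compound 1 to compound 3 (0.38 log units; beyond the scatter), a modest step and the first in this short series to lie beyond the scatter, even though each of the two smaller steps that span it stays within the scatter. Nothing measured here accounts for either step.

The compounds shown leave open whether an amine, a carboxylic acid or a chlorine atom on this same aromatic carbon would also leave the number within the scatter of compound 2. They also leave open how the number would respond to a longer chain between the anilide and the shared core, since all three compounds carry the same chain.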